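Chloro for Fluoro in a Cell Tolerance Screen

The compounds below may be only part of what the source reports. "The series", "measured", "known", "first", "only" and "open" are said of these compounds alone.

Compound 1 `N#Cc1ccc2c(Oc3ccc(Cl)cc3OCCn3ccc(=O)[nH]c3=O)cccc2c1`: > 100000 nM
Compound 2 `N#Cc1ccc2c(Oc3ccc(F)cc3OCCn3ccc(=O)[nH]c3=O)cc(F)cc2c1`: > 100000 nM

These values come from an ADME assay on MT2 cells (Homo sapiens) for cytotoxicity, read by MTT assay; a lower number here means that less compound is tolerated, a higher number that more compound is tolerated. For compound 1 the value shown is a limit of the assay rather than a number. For compound 2 the value shown is likewise a limit, so compound 2 stands at the limit of > 100000 nM in this assay, at which 2 of the 2 values shown sit. Compound 3 `N#Cc1ccc2c(Oc3ccc(Cl)cc3OCCn3ccc(=O)[nH]c3=O)cc(F)cc2c1` has not yet been measured; it differs from compound 2 by chloro in place of fluoro on an aromatic carbon. Within the data shown here, no measured step between compounds is available, so the expected step of a number no higher from compound 2 to compound 3 (the limit leaves the size open) in this assay is none beyond the usual scatter. Compound 3 is therefore estimated at 100000 nM, ranging from 50000 nM to 200000 nM.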

Compound 3, half-maximal cytotoxic concentration: 18000 nM
Estimate against measurement, compound 3: 5.6-fold (0.74 log units) above; measured number below the stated range.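

In this assay, chloro in place of fluoro on this aromatic carbon gives an at least 5.5-fold lower number from compound 2 to compound 3 (0.74 log units; beyond the scatter), and fluoro in place of hydrogen at the other changed place gives an at least 5.5-fold lower number from compound 1 to compound 3 (0.74 log units; beyond the scatter). Chloro alone or that fluoro alone therefore does not bring the number down to a measured value; of these three compounds, only compound 3 carries both groups and has one. Compound 2 stands at a limit of the assay, not a number: the limit of > 100000 nM in this assay, at which 2 of the 3 values shown sit.

Going by these compounds, whether bromo or methyl on this carbon would lower the number as well stays open. So does whether the same holds with an amine at the other changed place.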